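The source may report more compounds than this note shows. Statements on the series, on what has been measured and on what is new or still open speak of the compounds shown alone.

Compound 3 `Cc1ccc(C(=O)OC2CCC(CN3CCN(c4cc(=O)c5cc(C(F)(F)F)cc([N+](=O)[O-])c5s4)CC3)CC2)cc1` was tested in an ADME assay on Vero cells (Chlorocebus sabaeus) for cytotoxicity, read by MTT assay, with a stated time of 48 h; a lower number here means a stronger inhibitor, a higher number a weaker inhibitor. In this assay compound 3 gives only a limit, > 64 ug/mL. Compound 1 `CC(C)S(=O)(=O)OC1CCC(CN2CCN(c3cc(=O)c4cc(C(F)(F)F)cc([N+](=O)[O-])c4s3)CC2)CC1` likewise gives a limit in this assay, > 64 ug/mL. Compound 2 `O=C(OC1CCC(CN2CCN(c3cc(=O)c4cc(C(F)(F)F)cc([N+](=O)[O-])c4s3)CC2)CC1)C1CCC1` gives a limit as well, > 64 ug/mL. Accordingly the steps a step that the two limits leave unreadable from compound 1 to compound 3 and a step that the two limits leave unreadable from compound 2 to compound 3 cannot be read, nor can a step that the two limits leave unreadable from compound 1 to compound 2, since every value shown sits at the limit of > 64 ug/mL in this assay, at which 3 of the 3 values shown sit. Compound 4 `O=c1cc(N2CCN(CC3CCC(OS(=O)(=O)c4ccccc4)CC3)CC2)sc2c([N+](=O)[O-])cc(C(F)(F)F)cc12` differs from compound 3 by phenylsulfonyl in place of (4-methylphenyl)carbonyl on an oxygen on a saturated carbon. Within the data shown here, no measured step gives a readable size for a change of this kind, so no step beyond the scatter is expected in this assay. Compound 4 is therefore expected to give 100 ug/mL, estimated between 60 ug/mL and 200 ug/mL, and the step that the limit leaves unreadable from compound 3 to compound 4 is expected to be flat, most likely again only a limit.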

Compound 4, half-maximal inhibitory concentration: > 64 ug/mL
Compound 4: no number, only a limit; the forecaster's own chance of this, stated with the estimate: 85%; the middle value lies beyond the limit too.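

Among these compounds, no step among compound 1, compound 2, compound 3 and compound 4 can be read in this assay, as each gives only a limit: the limit of > 64 ug/mL in this assay, at which 4 of the 4 values shown sit. The compounds shown leave open whether any of these groups on the oxygen changes the value in this assay at all.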